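A few compounds are considered here, and "the series" means these few. Any claim that something is new, unique, unknown or untested is made for them only; others in the source may bear on it.

Measured compounds:
Compound 1, `C[C@@H](Cn1ccc(-c2ccc(C#N)c(Cl)c2)n1)NC(=O)C1CC(=O)C1`, gives 3040 nM in a functional assay on LNCaP cells (Homo sapiens) for antiproliferative activity, read by CCK-8 assay, with a stated time of 6 days; a higher number here means a weaker inhibitor, a lower number a stronger inhibitor.
Compound 2, `CC(=O)c1ccc(S(=O)(=O)N[C@@H](C)Cn2ccc(-c3ccc(C#N)c(Cl)c3)n2)cc1`, gives 5230 nM in this assay.

Compound 2 holds the higher of the two numbers, but its gap to compound 1 lies within the scatter, so the two are read as alike. Compound 3, `C[C@@H](Cn1ccc(-c2ccc(C#N)c(Cl)c2)n1)NS(=O)(=O)c1cn(C)cn1`, follows from compound 2 by one change: 1-methyl-1H-imidazol-4-yl in place of 4-acetylphenyl on a sulfonyl sulfur. Among the measured compounds shown here, no measured pair isolates this change, so nothing in the set tells how the group on the sulfonyl sulfur sets the number. Both measured compounds sit in the same weak range, and compound 3 keeps the shared core and the sulfonamide link of compound 2. In this assay the expected step is therefore a 1.1-fold higher number from compound 2 to compound 3 (0.02 log units; within the scatter), with no direction expected beyond the scatter. Compound 3 is estimated at 5500 nM, with a range from 1800 nM to 17000 nM.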

Compound 3, half-maximal inhibitory concentration: > 30000 nM
Compound 3 ended at the assay's limit; the forecaster's own chance of this, stated with the estimate: 20%; at least 5.4-fold (0.73 log units) between middle value and limit.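

In this assay compound 3 gives > 30000 nM, which is a limit of the assay and not a number: the limit of > 30000 nM in this assay, at which 1 of the 3 values shown sits.

The group on the sulfonyl sulfur does move the number, since 1-methyl-1H-imidazol-4-yl in place of 4-acetylphenyl gives an at least 5.7-fold higher number from compound 2 to compound 3 (0.75 log units; beyond the scatter), so the shared core and the sulfonamide link alone do not keep a measurable value. On the amine nitrogen, (1-methyl-1H-imidazol-4-yl)sulfonyl in place of (3-oxocyclobutyl)carbonyl gives an at least 9.8-fold higher number from compound 1 to compound 3 (0.99 log units; beyond the scatter).

This single swap changes the ring size, the hetero atoms and the acetyl carbonyl together, so the compounds shown cannot tell which of these carries the loss. Whether a plain phenyl or a 4-carboxyphenyl on the sulfonyl sulfur would keep a measurable value remains an open question.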